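Trimming the ether side chain: compound 3 to compound 4

The source may hold more compounds than are shown below. What is called first, only, known or untested is meant among the compounds shown, and "the series" means these compounds.

Compound 1 `CCC#CCOc1cccc2ccc(N)nc12` gives only a limit in an assay on cells with melanin-concentrating hormone receptor 1 (Homo sapiens) as the target, read by radioligand binding (on this read-out higher numbers stand for weaker inhibition and lower numbers for stronger inhibition), reported as > 2000 nM. Compound 2 `Nc1ccc2cccc(OCCC3CC3)c2n1` gives 492 nM in this assay, and compound 3 `CCC(CC)C(C)Oc1cccc2ccc(N)nc12` gives 191 nM, the lowest of the two numbers shown. Within the data shown here, the one measured step, an at least 4.0-fold lower number from compound 1 to compound 2 (0.60 log units; beyond the scatter), sits on the same oxygen-bound chain but concerns a different change, so it does not read directly onto compound 4 `CCCC(C)Oc1cccc2ccc(N)nc12`, which differs from compound 3 by hydrogen in place of ethyl on a saturated chain carbon bound to two saturated chain carbons. Of the two numbers shown, compound 2 gives the higher one at 492 nM. With only that to go on, a modest weakening is expected for compound 4, a 2.1-fold higher number from compound 3 to compound 4 (0.32 log units; beyond the scatter). Compound 4 is estimated at 400 nM, with a range from 150 nM to 1100 nM.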

Compound 4, half-maximal inhibitory concentration: 105 nM
The estimate for compound 4 lay 3.8-fold (0.58 log units) above the measured number; measured number below the stated range.
By their numbers in this assay, from the lowest: compounds 4 and 3 (each within the scatter of the next); then compound 2. At a limit, above all of these: compound 1.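

Hydrogen in place of ethyl on a saturated chain carbon bound to two saturated chain carbons does not separate the two compounds in this assay: a 1.8-fold lower number from compound 3 to compound 4 (0.26 log units; within the scatter). The 1-methylbutyl chain does stand apart from the two other ether chains, with a 4.7-fold lower number from compound 2 to compound 4 (0.67 log units; beyond the scatter) against 2-cyclopropylethyl and an at least 19-fold lower number from compound 1 to compound 4 (1.27 log units; beyond the scatter) against pent-2-yn-1-yl. The last of these steps rests on a limit for compound 1, not a number: the limit of > 2000 nM in this assay, at which 1 of the 4 values shown sits.

Open, from the compounds shown here alone, is what a straight pentyl chain on the same oxygen would give, which would test the methyl branch of 1-methylbutyl. Also open, going by these compounds, is the effect of an amine or a hydroxyl at the end of that chain.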